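The source may hold more compounds than are shown below. What is called first, only, known or untested is meant among the compounds shown, and "the series" means these compounds.

Compound 1 `Cc1cc(C)c(CN2CCc3c(Cl)cc([C@@H](CO)[C@@H]4CCOC4)c(Cl)c3C2=O)c(=O)[nH]1` is tested in a functional assay on KARPAS-422 cells (Homo sapiens) for antiproliferative activity, read by resazurin assay, with a stated time of 72 h (on this read-out higher numbers stand for weaker inhibition and lower numbers for stronger inhibition), where compound 1 gives 3950 nM; that is the only single number shown for compound 1 in this assay, and it lies at the weaker end of what the study shows. Two related compounds from the same study each carry two entries in this assay. Compound 2 `COC(c1cc(Cl)c2c(c1Cl)C(=O)N(Cc1c(C)cc(C)[nH]c1=O)CC2)C1CCN(C2COC2)CC1` gives 2260 nM; 25 nM (2 entries) in this assay, and compound 3 `COC(c1cc(Cl)c2c(c1Cl)C(=O)N(Cc1c(C)cc(C)[nH]c1=O)CC2)C1CCN(C(C)=O)CC1` gives 1620 nM; 22 nM (2 entries) in this assay; in each case one entry sits close to compound 1 while the other is far lower, as shown by the several entries of compound 2 in this assay, 2260 nM; 25 nM (2 entries) and (the several entries of compound 3 in this assay, 1620 nM; 22 nM (2 entries)), so the shared core can reach strong inhibition. Compound 4 `Cc1cc(C)c(CN2CCc3c(Cl)cc([C@H](CO)[C@H]4CCOC4)c(Cl)c3C2=O)c(=O)[nH]1` has not been measured in this assay. It differs from compound 1 only in configuration: the two compounds have the same atoms and bonds and differ only in configuration as drawn: 2 of 2 stereo elements differ (all stereocentres are inverted: mirror images); a stereocentre at a saturated chain carbon is drawn S in compound 1 and R in compound 4; a stereocentre at a saturated ring carbon is drawn S in compound 1 and R in compound 4. Among the measured compounds shown here, no measured step between enantiomers is available, so the size of the step is an estimate, and a sizeable step toward stronger inhibition is expected a 9.9-fold lower number from compound 1 to compound 4 (0.99 log units; beyond the scatter), because compound 1 at 3950 nM leaves room below it. Compound 4 is expected to give 400 nM, between 25 nM and 4000 nM.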

Compound 4, half-maximal inhibitory concentration: 15 nM
Estimate against measurement, compound 4: 27-fold (1.43 log units) above; the measured number lies below the stated range.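

In this assay, among the compounds shown here, inverting both stereocentres gives a 260-fold lower number from compound 1 to compound 4 (2.42 log units; beyond the scatter), so the activity of this series can depend heavily on three-dimensional arrangement, which the earlier compounds could not show. The gap can be traced to configuration alone, because nothing else separates the pair: the fact that compounds 1 and 4 differ only in the configuration as drawn. The weak result for compound 1 therefore comes from how its atoms are arranged, not from which atoms it contains, since the same atoms and bonds give strong inhibition in compound 4.

Going by these compounds, both stereocentres change together in this pair, so what each contributes on its own stays open. It is also unknown whether the strong inhibition of compound 4 would survive with an amine or a carboxylic acid in place of its alcohol.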